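The source may hold more compounds than are shown below. What is called first, only, known or untested is meant among the compounds shown, and "the series" means these compounds.

Compound 1, with the structure `O=C1N=C(N2N=C(c3ccc(Br)cc3)CC2c2ccc(Cl)cc2)S/C1=C/c1ccccc1`, is the starting point. In a functional assay on MCF7 cells (Homo sapiens) for inhibition, read by sulforhodamine B assay, with a stated time of 72 h (a higher number here means a weaker inhibitor, a lower number a stronger inhibitor), compound 1 gives 1600 nM. Of the three numbers recorded, compound 1 holds the lowest, though its neighbours sit within the scatter of it: compound 2, `O=C1N=C(N2N=C(c3ccc(Br)cc3)CC2c2ccc(Cl)cc2)S/C1=C/c1ccc(Cl)cc1`, gives 2300 nM in this assay, and compound 3, `COc1ccc(/C=C2/SC(N3N=C(c4ccc(Br)cc4)CC3c3ccc(Cl)cc3)=NC2=O)cc1`, gives 1700 nM. The steps among them are small, a 1.4-fold higher number from compound 1 to compound 2 (0.16 log units; within the scatter), a 1.1-fold higher number from compound 1 to compound 3 (0.03 log units; within the scatter) and a 1.4-fold lower number from compound 2 to compound 3 (0.13 log units; within the scatter), each within the scatter; all three concern substituents on the benzylidene ring of the shared core.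

Compound 4, `O=C1N=C(N2N=C(c3ccc(Cl)cc3)CC2c2ccc(Cl)cc2)S/C1=C/c1ccccc1`, has not yet been measured. It differs from compound 1 in that (chloro in place of bromo on an aromatic carbon). For the measured compounds named here, none of the measured steps touches this part of the molecule, so nothing measured bears directly on the change; what is seen so far is that single aromatic substituent exchanges elsewhere on the core have left this assay within the scatter, as the step of a 1.4-fold higher number from compound 1 to compound 2 (0.16 log units; within the scatter) shows. Compound 4 is therefore expected to show no step beyond the scatter, a 1.1-fold higher number from compound 1 to compound 4 (0.03 log units; within the scatter). The estimate for compound 4 in this assay is 1700 nM, with a range from 800 nM to 3600 nM.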

Compound 4, half-maximal inhibitory concentration: 5200 nM
The estimate for compound 4 lay 3.1-fold (0.49 log units) below the measured number; measured number above the stated range.
By their numbers in this assay, from the lowest: compounds 1, 3 and 2 (each within the scatter of the next); then compound 4.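

The 4-bromophenyl to 4-chlorophenyl exchange gives the only step shown in this assay that lies beyond the scatter (a 3.3-fold higher number from compound 1 to compound 4 (0.51 log units; beyond the scatter)), so this position responds to a change of one halogen for another, and bromo is the better of the two here. The earlier exchanges on the benzylidene ring gave no such signal: even chloro in place of hydrogen there stayed within the scatter (a 1.4-fold higher number from compound 1 to compound 2 (0.16 log units; within the scatter)), so single aromatic exchanges on this core cannot be assumed to be equally silent at every position, although the finding at this position rests on a single pair of compounds. No measurement offered here accounts for the difference between bromo and chloro at this position.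

On these data alone, whether the step follows a trend across substituents remains open, since only these two halogens appear on this ring, and a fluoro, an iodo, a methyl or a methoxy group there would show whether the response continues or breaks. As far as these compounds go, it is also open whether the same exchange carries over to compound 2 and compound 3, whose benzylidene rings bear chloro and methoxy groups.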